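Cyclohexyl for tert-butyl in a rat exposure series

The source may report more compounds than this note shows. Statements on the series, on what has been measured and on what is new or still open speak of the compounds shown alone.

Compound 2 `C=CCNC(=O)C(=O)C(CCC)NC(=O)[C@@H]1[C@@H]2[C@H](CN1C(=O)[C@@H](NC(=O)N[C@@H](CN1CCC(C)(C)CC1=O)C(C)(C)C)C(C)(C)C)C2(C)C` stands second highest of the three numbers in an ADME assay on the whole organism (plasma) for pharmacokinetics, with Rattus norvegicus as the target, at a dose of 10 mg/kg by the oral route; a higher number here means more compound in the circulation at the dose given, a lower number less compound in the circulation: compound 2 gives 1580 ng.h/mL, compound 3 `C=CCNC(=O)C(=O)C(CC1CC1)NC(=O)[C@@H]1[C@@H]2[C@H](CN1C(=O)[C@@H](NC(=O)N[C@@H](CN1CCC(C)(C)CC1=O)C(C)(C)C)C(C)(C)C)C2(C)C` gives 2460 ng.h/mL, and compound 1 `C=CCNC(=O)C(=O)C(CCC)NC(=O)[C@@H]1[C@@H]2[C@H](CN1C(=O)[C@@H](NC(=O)N[C@@H](CN1CCCNC1=O)C(C)(C)C)C(C)(C)C)C2(C)C` gives 46.2 ng.h/mL. The step of a 1.6-fold higher number from compound 2 to compound 3 (0.19 log units; within the scatter) lies within the scatter, whereas a 34-fold higher number from compound 1 to compound 2 (1.53 log units; beyond the scatter) is large. Compound 4 `C=CCNC(=O)C(=O)C(CCC)NC(=O)[C@@H]1[C@@H]2[C@H](CN1C(=O)[C@@H](NC(=O)N[C@@H](CN1CCC(C)(C)CC1=O)C(C)(C)C)C1CCCCC1)C2(C)C` differs from compound 2 by cyclohexyl in place of tert-butyl on a saturated chain carbon bound to an amide-type nitrogen and a carbonyl carbon. Neither measured step involves the tert-butyl group: one exchanges a ring-bearing group elsewhere in the molecule, the other exchanges cyclopropyl for ethyl. Among the compounds with values here, no measured step therefore bears directly on this change, and a step in this assay no larger than the scatter is expected, a 1.3-fold lower number from compound 2 to compound 4 (0.12 log units; within the scatter). Compound 4 is estimated at 1200 ng.h/mL, with a range from 400 ng.h/mL to 3500 ng.h/mL.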

Compound 4, area under the concentration-time curve: 1490 ng.h/mL
For compound 4 the middle estimate is 1.2-fold (0.09 log units) below the measured one; low and high end bracket the measured number.
By their numbers in this assay, from the lowest: compound 1; then compounds 4, 2 and 3 (each within the scatter of the next).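

In this assay, cyclohexyl in place of tert-butyl on this saturated chain carbon gives a 1.1-fold lower number from compound 2 to compound 4 (0.03 log units; within the scatter) and lies within the scatter, so compound 2 and compound 4 cannot be told apart here. Within the data shown here, this is the first measured step at this position, and it is far smaller than a 34-fold higher number from compound 1 to compound 2 (1.53 log units; beyond the scatter) at the other site. Nothing measured here accounts for the result.

From the compounds shown here alone, whether methyl, or a cyclohexyl ring carrying an amine, would give a similar number at this position stays open. So does whether cyclohexyl behaves alike with cyclopropyl in place of ethyl.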